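Ortho methoxy in place of ortho chloro on the amide

The source may hold more compounds than are shown below. What is called first, only, known or untested is meant among the compounds shown, and "the series" means these compounds.

Measured compounds:
compound 1 `COc1cccc(C(=O)NCc2ccc(CNS(=O)(=O)c3ccc(C)cc3)cc2)c1`: 28%
compound 2 `COc1ccccc1C(=O)NCc1ccc(CNS(=O)(=O)c2ccccc2)cc1`: "not active" (no number reported)
compound 3 `Cc1ccc(S(=O)(=O)NCc2ccc(CNC(=O)c3ccccc3Cl)cc2)cc1`: 26%

In a functional assay on the whole organism for inhibition, with Mus musculus as the target, with stated times of 30 min and 2 h, at a dose of 10 mg/kg by the intraperitoneal route (on this read-out lower numbers stand for less inhibition and higher numbers for more inhibition at the one dose given (going by the name of the read-out)), compound 3 sits lowest of the two numbers shown, with compound 1 nearest and within the scatter; compound 2 gave no number. Within the data shown here, the one measured step that bears here is a number 2 percentage points lower from compound 1 to compound 3 (within the scatter), a change of the aryl group on the carbonyl that moved the read-out only within the scatter. Compound 4 `COc1ccccc1C(=O)NCc1ccc(CNS(=O)(=O)c2ccc(C)cc2)cc1` differs from compound 3 by methoxy in place of chloro on an aromatic carbon. Compound 2 carries the same 2-methoxyphenyl group on the carbonyl, though with a different sulfonyl ring, and was reported inactive, so the outcome is uncertain. A modest drop, a number 8 percentage points lower from compound 3 to compound 4 (within the scatter), is expected. Compound 4 is estimated at 18%, between 0% and 38%.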

Compound 4, a percentage reported as inhibition, in the whole organism at one dose (the size of the read-out at that dose, not a potency): "not active" (no number reported)
Compound 4: no number reported, so the estimate cannot be set against anything.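

Among these compounds, compound 4 is reported as not active, with no number, so no step from compound 3 to compound 4 can be read in this assay. No measurement at hand explains this result. As far as these compounds go, how large a difference the 2-methoxyphenyl group makes against the 2-chlorophenyl group stays open.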